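Permeability of a Carbamate Replacing a Propanoyl Amide

The source may hold more compounds than are shown below. What is called first, only, known or untested is meant among the compounds shown, and "the series" means these compounds.

Three close relatives share one core and have been run in an ADME assay on Caco-2 cells (Homo sapiens) for permeability, in the apical to basolateral direction; on this read-out higher numbers stand for higher permeability and lower numbers for lower permeability. Compound 1 `Cn1cncc1CN1CC(N(CC2CCN(C(=O)CNC(=O)OC(C)(C)C)CC2)S(=O)(=O)c2ccccn2)Cc2cc(C#N)ccc21` gives 0.5 10^-6 cm/s. Compound 2 `CCC(=O)N1CCC(CN(C2Cc3cc(C#N)ccc3N(Cc3cncn3C)C2)S(=O)(=O)c2ccccn2)CC1` gives 0.5 10^-6 cm/s, and compound 3 `Cn1cncc1CN1CC(N(CC2CCN(C(=O)C3CC3)CC2)S(=O)(=O)c2ccccn2)Cc2cc(C#N)ccc21` gives 0.5 10^-6 cm/s. Compound 2 therefore stands level with both neighbours: no change at the digits printed from compound 1 to compound 2 (within the scatter), no change at the digits printed from compound 2 to compound 3 (within the scatter), and the pair that skips it reads no change at the digits printed from compound 1 to compound 3 (within the scatter). All three differences sit on the same carbonyl carbon, and none moved this assay beyond its scatter.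

Compound 4 `Cn1cncc1CN1CC(N(CC2CCN(C(=O)OC(C)(C)C)CC2)S(=O)(=O)c2ccccn2)Cc2cc(C#N)ccc21` is the next member, not yet measured. Its change from compound 2 is tert-butoxy in place of ethyl on a carbonyl carbon. This is the same site where the three known steps sat, and each of those three steps was flat, so the expectation for this assay is a step of no size beyond the scatter: no change at the digits printed from compound 2 to compound 4 (within the scatter). Compound 4 is thus expected to give 0.5 10^-6 cm/s, with a range from 0.25 10^-6 cm/s to 1 10^-6 cm/s.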

Compound 4, apparent permeability: 15.5 10^-6 cm/s
Estimate against measurement, compound 4: 31-fold (1.49 log units) below, outside the stated range (above it).
By their numbers in this assay, from the lowest: compounds 1, 2 and 3 (each within the scatter of the next); then compound 4.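

For the compounds shown here, the carbonyl carbon is not as unresponsive in this assay as the earlier compounds suggested: a 31-fold higher number from compound 2 to compound 4 (1.49 log units; beyond the scatter) and a 31-fold higher number from compound 3 to compound 4 (1.49 log units; beyond the scatter) and a 31-fold higher number from compound 1 to compound 4 (1.49 log units; beyond the scatter) all show a large rise once tert-butoxy sits on it. Compound 1 also holds a (tert-butoxycarbonyl)amino group, on a saturated chain carbon, yet it stays level with compounds 2 and 3, so among these compounds the high number goes with tert-butoxy placed directly on the carbonyl carbon, not with its mere presence in the molecule. Nothing shown here explains the jump.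

From the compounds shown here alone, it remains open whether the jump needs tert-butoxy itself or would also appear with methoxy or ethoxy on the same carbonyl carbon. What a dimethylamino group there would give is open too.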